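The source may report more compounds than this note shows. Statements on the series, on what has been measured and on what is new or still open speak of the compounds shown alone.

Measured so far:
compound 1, `N#C/C(=N\O)C(=O)Nc1cccc(C(F)(F)F)c1`: 4.88
compound 2, `N#C/C(=N\O)C(=O)Nc1ccc([N+](=O)[O-])cc1`: 4.61

In a physicochemical assay for acid dissociation, using potentiometric titration, compound 1 gives 4.88, and compound 2 gives 4.61. Compound 2 holds the lower of the two numbers, yet compound 1 sits only a little above it, a gap that falls within the scatter of this kind of measurement, so the two cannot be put in order. No single-point comparison between measured compounds is available, so nothing about the size of a step can be read from the data themselves.

The next compound, compound 3, `Cc1ccc(NC(=O)/C(C#N)=N/O)cc1`, has not yet been measured. It departs from compound 2 in one place: methyl in place of nitro on an aromatic carbon. Among the compounds with values here, with no measured step to lean on, the expectation for this assay rests on the structural change alone. A modest rise beyond the scatter is expected, that is, a step of a number 0.59 log units higher from compound 2 to compound 3 (beyond the scatter). Compound 3 is therefore expected to give about 5.2, somewhere between 4.8 and 5.6.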

Compound 3, acid dissociation constant: 5.07
For compound 3 the middle estimate is 0.13 log units above the measured one; the measured number falls inside the stated range.
By their numbers in this assay, from the lowest: compounds 2, 1 and 3 (each within the scatter of the next, the first and the last beyond it).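

In this assay, within the data shown here, methyl in place of nitro gives a number 0.46 log units higher from compound 2 to compound 3 (beyond the scatter), the first step that can be read between two compounds differing in one place. It shows that the number responds to what sits on this aromatic carbon, para to a group of 8 heavy atoms, and that this exchange of a nitro group for a methyl group moves it by a modest amount. Nothing in the data shown explains why the number moves.

Where other groups at this carbon would fall, such as an amine or a carboxylic acid, remains open, as does whether plain hydrogen there would lie closer to compound 2 or to compound 3. Among these compounds, with only one step available, it is also unknown whether the same exchange would give a similar step at another position on the ring.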